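Butyl at the para carbon of the carbamate aryl ring

The source may report more compounds than this note shows. Statements on the series, on what has been measured and on what is new or still open speak of the compounds shown alone.

Compound 1 `C=C1C(=O)OC[C@H]1CCOC(=O)Nc1ccccc1` is the simplest member of this set. Going by the values given here, in a functional assay on RAW264.7 cells (Mus musculus) for inhibition, with a stated time of 30 min (on this read-out higher numbers stand for weaker inhibition and lower numbers for stronger inhibition), compound 1 gives 390 nM, the lowest of the three numbers measured so far. Compound 2 `C=C1C(=O)OC[C@@H]1CCOC(=O)Nc1ccc(Br)cc1` gives 720 nM, which is within the scatter of compound 1. Compound 3 `C=C1C(=O)OC[C@@H]1CCOC(=O)Nc1ccc(C)c(C)c1` gives 1450 nM, beyond the scatter and the furthest from compound 1. Both substituted aryl rings thus give higher numbers than the bare ring, though only compound 3 does so beyond the scatter.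

Compound 4 `C=C1C(=O)OC[C@H]1CCOC(=O)Nc1ccc(CCCC)cc1` carries the change (butyl in place of hydrogen on an aromatic carbon). Since the other two aryl substituents gave numbers at or above compound 1, the step of a 1.9-fold higher number from compound 1 to compound 4 (0.28 log units; within the scatter) is expected to be modest and towards weaker inhibition. Compound 4 is estimated at 750 nM, with a range from 250 nM to 2200 nM.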

Compound 4, half-maximal inhibitory concentration: 620 nM
Compound 4: middle estimate off by 1.2-fold (0.08 log units), on the high side; the range from low to high includes it.
By their numbers in this assay, from the lowest: compounds 1, 4, 2 and 3 (each within the scatter of the next, the first and the last beyond it).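

In this assay, going by these compounds alone, butyl in place of hydrogen on an aromatic carbon gives a 1.6-fold higher number from compound 1 to compound 4 (0.20 log units; within the scatter), the only single-place step so far. This place, para to a large group, therefore tolerates butyl, with compound 4 remaining within the scatter of compound 1. No available evidence explains this result.

Going by these compounds, whether a longer chain such as octyl would also stay within the scatter remains open. So does the outcome with an amine or a carboxylic acid at this carbon.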